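A Methoxy Group Added to the Anilide of Compound 2

The compounds below may be only part of what the source reports. "The series", "measured", "known", "first", "only" and "open" are said of these compounds alone.

Compound 1 `CNC(=O)c1cc(Oc2ccc(/C=C/c3ccccn3)cc2)ccn1` and compound 2 `O=C(Nc1ccccc1)c1cc(Oc2ccc(/C=C/c3ccccn3)cc2)ccn1` share one core and differ only in the group on the amide-type nitrogen. In a functional assay on HepG2 cells (Homo sapiens) for antiproliferative activity, read by CCK-8 assay, with a stated time of 48 h (on this read-out lower numbers stand for stronger inhibition and higher numbers for weaker inhibition), compound 1 gives 21600 nM, and compound 2 gives 30200 nM. Within the data shown here, compound 2 thus holds the higher of the two numbers recorded so far, yet its only neighbour is compound 1 and the gap is small: a 1.4-fold higher number from compound 1 to compound 2 (0.15 log units; within the scatter), which stays inside the usual scatter. Compound 3 `COc1ccc(NC(=O)c2cc(Oc3ccc(/C=C/c4ccccn4)cc3)ccn2)cc1` arises from compound 2 by a single change, (methoxy in place of hydrogen on an aromatic carbon). Among the measured compounds shown here, no measured pair shows what adding a methoxy at this place does; the one measured step exchanges the whole substituent on the amide-type nitrogen and stays within the scatter, so it bears on the same region of the molecule but not on the same change. For the measured compounds named here, with no direct precedent and both measured numbers close together, the step expected for compound 3 is none beyond the scatter, a 1.0-fold lower number from compound 2 to compound 3 (0.00 log units; within the scatter). Compound 3 is therefore estimated at 30000 nM in this assay, with a range from 12000 nM to 75000 nM.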

Compound 3, half-maximal inhibitory concentration: 30000 nM
Beside the measured number, compound 3's estimate shows no gap at the digits printed; the range from low to high includes it.
By their numbers in this assay, from the lowest: compounds 1, 3 and 2 (each within the scatter of the next).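

Adding the methoxy on the aromatic carbon para to a large group, which turns phenyl into 4-methoxyphenyl, gives a 1.0-fold lower number from compound 2 to compound 3 (0.00 log units; within the scatter) in this assay, and this is the first direct reading of this change at this place. The wider exchange on the amide-type nitrogen, 4-methoxyphenyl in place of methyl, gives a 1.4-fold higher number from compound 1 to compound 3 (0.14 log units; within the scatter), so methyl, phenyl and 4-methoxyphenyl on that nitrogen all lie within the scatter of one another, and the methoxy adds nothing that can be told apart from the two earlier compounds. No evidence is available on the reason for this flat result.

The compounds shown carry only this one substituent on the ring, so it remains open whether another group on the same carbon, such as an amine or a carboxylic acid, would move the number beyond the scatter, and whether a methoxy on a different carbon of that ring would do so. As far as these compounds go, it also remains open whether a longer chain on the amide-type nitrogen would separate from these three compounds.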